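From methyl to cyclohexyl on an aromatic nitrogen

A few compounds are considered here, and "the series" means these few. Any claim that something is new, unique, unknown or untested is made for them only; others in the source may bear on it.

In a functional assay on brain (Rattus norvegicus, strain Wistar) for inhibition (a higher number here means a weaker inhibitor, a lower number a stronger inhibitor), compound 1 `CCCCOc1ccc(-c2c(C)[nH]c(=O)n2C)cc1` gives 5100 nM, compound 2 `CCCCCCCCOc1ccc(-c2c(C)[nH]c(=O)n2C)cc1` gives 4000 nM and compound 3 `CCCCCCCCCCOc1ccc(-c2c(C)[nH]c(=O)n2C)cc1` gives 6900 nM. These three share a core and differ only in their saturated chain. Compound 3 stands within the scatter of both others, as the steps show: a 1.4-fold higher number from compound 1 to compound 3 (0.13 log units; within the scatter) and a 1.7-fold higher number from compound 2 to compound 3 (0.24 log units; within the scatter). The remaining step, a 1.3-fold lower number from compound 1 to compound 2 (0.11 log units; within the scatter), is just as small.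

Compound 4 `CCCCCCCCCCOc1ccc(-c2c(C)[nH]c(=O)n2C2CCCCC2)cc1` keeps the chain of compound 3 and changes another part of the molecule: cyclohexyl in place of methyl on an aromatic nitrogen. Within the data shown here, none of the measured steps touches that nitrogen, so they bear on this change only indirectly. They show that these three chains left this assay values within the scatter, and they give no direction for the new group. No step beyond the scatter is therefore expected, though with real uncertainty. The expected step is a 1.4-fold lower number from compound 3 to compound 4 (0.14 log units; within the scatter). Compound 4 is estimated at 5000 nM, with an expected range of 1500 nM to 15000 nM.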

Compound 4, half-maximal inhibitory concentration: 10500 nM
Compound 4: middle estimate off by 2.1-fold (0.32 log units), on the low side; the range from low to high includes it.
By their numbers in this assay, from the lowest: compounds 2, 1, 3 and 4 (each within the scatter of the next, the first and the last beyond it).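

Replacing methyl with cyclohexyl on the aromatic nitrogen gives a 1.5-fold higher number from compound 3 to compound 4 (0.18 log units; within the scatter) in this assay, so this step stays within the scatter even though the group grows from 1 heavy atom to 6 and gains a six-membered non-aromatic ring. The earlier compounds shown here varied only the saturated chain, whereas this pair shows that, with the chain of compound 3 in place, the nitrogen can carry either group without a clear difference in this assay. No measurement shown here offers an explanation for this result.

On these data alone, it remains open whether cyclohexyl on this nitrogen would give a similar result with the shorter chains of compound 1 and compound 2. As far as these compounds go, it is also open what a phenyl ring, a hydrogen or a carboxylic acid-bearing chain would do at this position.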